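Taking a second acetyl off compound 3

The source may report more compounds than this note shows. Statements on the series, on what has been measured and on what is new or still open speak of the compounds shown alone.

compound 1 `C=C1CC[C@@H]2[C@](C)(CO[Si](C(C)C)(C(C)C)C(C)C)[C@H](OC(C)=O)CC[C@@]2(C)[C@@H]1C/C=C1/C(=O)OC[C@H]1OC(C)=O`: 7.56 uM
compound 2 `C=C1CC[C@@H]2[C@](C)(CO[Si](C)(C)C(C)(C)C)[C@H](OC(C)=O)CC[C@@]2(C)[C@@H]1C/C=C1/C(=O)OC[C@H]1OC(C)=O`: 1.22 uM
compound 3 `C=C1CC[C@@H]2[C@](C)(CO[Si](C)(C)C(C)(C)C)[C@H](O)CC[C@@]2(C)[C@@H]1C/C=C1/C(=O)OC[C@H]1OC(C)=O`: 3.41 uM

In a functional assay on ASK cells (Rattus norvegicus) for cytotoxicity, read by sulforhodamine B assay (on this read-out lower numbers stand for an effect already at smaller amounts and higher numbers for an effect only at larger amounts of compound), compound 3 gives 3.41 uM, the middle of the three numbers, above compound 2 and under compound 1. The unmeasured compound 4 `C=C1CC[C@@H]2[C@](C)(CO[Si](C)(C)C(C)(C)C)[C@H](O)CC[C@@]2(C)[C@@H]1C/C=C1/C(=O)OC[C@H]1O` differs from compound 3 by hydrogen in place of acetyl on an oxygen on a saturated carbon, acetoxy to hydroxy. The closest guide is the same swap at another oxygen, a 2.8-fold higher number from compound 2 to compound 3 (0.45 log units; beyond the scatter). The other measured change, a 6.2-fold lower number from compound 1 to compound 2 (0.79 log units; beyond the scatter), concerns a different group and says little here. With a single precedent, a higher number of similar size is expected, though with wide uncertainty. The expected change is a 2.3-fold higher number from compound 3 to compound 4 (0.37 log units; beyond the scatter). Compound 4 is estimated at 8 uM, within a range of 3.5 uM to 18 uM.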

Compound 4, concentration for half-maximal effect: 15.5 uM
For compound 4 the middle estimate is 1.9-fold (0.29 log units) below the measured one, and the stated range covers the measured number.
By their numbers in this assay, from the lowest: compound 2; then compound 3; then compound 1; then compound 4.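

In this assay, acetoxy to hydroxy at this second oxygen gives a 4.5-fold higher number from compound 3 to compound 4 (0.66 log units; beyond the scatter) and so moves the number the same way as the earlier swap at the other oxygen, a 2.8-fold higher number from compound 2 to compound 3 (0.45 log units; beyond the scatter) in that case. The higher number on losing an acetyl is therefore not tied to one oxygen in this pair of steps. No measurement shown explains the rise.

Still open, as far as these compounds go, is whether acetyl itself matters or whether another group on this oxygen, such as a longer butyryl chain or a methyl ether, would give a similar number.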